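The source may report more compounds than this note shows. Statements on the series, on what has been measured and on what is new or still open speak of the compounds shown alone.

Of the compounds shown here, three with a shared core have been tested in a functional assay on PC-3 cells (Homo sapiens) for antiproliferative activity, read by MTT assay, with a stated time of 48 h; on this read-out lower numbers stand for stronger inhibition and higher numbers for weaker inhibition. Compound 1 `Cc1cnc(Nc2ccc(S(C)(=O)=O)cc2)nc1Nc1nc2ccc(Cl)cc2s1` gives 13400 nM. Compound 2 `Cc1cnc(Nc2ccc(C(C)C)cc2)nc1Nc1nc2ccccc2s1` gives only a limit of the assay, > 50000 nM. Compound 3 `COc1ccc2nc(Nc3nc(Nc4ccc(S(N)(=O)=O)cc4)ncc3C)sc2c1` likewise gives only a limit, > 50000 nM. Among the compounds with values here, compound 2 therefore stands at the edge of what this assay can report, the point at which two of the three readings sit (the limit of > 50000 nM in this assay, at which 2 of the 3 values shown sit), and the reading of compound 1 is the only one that is a number rather than a limit.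

Compound 4 `Cc1cnc(Nc2cccc(F)c2)nc1Nc1nc2ccccc2s1` differs from compound 2 in one place: 3-fluorophenyl in place of 4-isopropylphenyl on a nitrogen on an aromatic ring, in words, 3-fluorophenyl in place of 4-isopropylphenyl on a nitrogen on an aromatic ring. Within the data shown here, no measured pair shows this change, so its size cannot be read from the data. Because compound 2 gives only a limit, an outcome for compound 4 that also ends at the limit would look like no change, while a numerical reading would mean a gain of unknown size. The estimate given here implies a step of an at least 1.2-fold lower number from compound 2 to compound 4 (0.09 log units; that floor lies within the scatter) in this assay, within the scatter or slightly toward stronger inhibition. In this assay compound 4 is expected to give about 40000 nM, within a range from 10000 nM to 150000 nM.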

Compound 4, half-maximal inhibitory concentration: > 50000 nM
Compound 4: no number, only a limit (the forecaster's own chance of this, stated with the estimate: 55%); middle value at least 1.2-fold (0.09 log units) away from the limit.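

In this assay compound 2 and compound 4 both end at a limit of the assay rather than a number, so no step between them can be read: the limit of > 50000 nM in this assay, at which 3 of the 4 values shown sit.

The compounds shown leave open whether 3-fluorophenyl in place of 4-isopropylphenyl changes the reading at all, and if so, in which direction and by how much.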